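One Substituent Change on an Aromatic Nitrogen

The source may hold more compounds than are shown below. What is called first, only, known or untested is meant among the compounds shown, and "the series" means these compounds.

compound 1 `CCOC(=O)C1=Cc2ccccc2OC1(OCc1cc(-c2ccc(OC)cc2)no1)C(F)(F)F`: > 150000 nM
compound 2 `CCOC(=O)C1=Cc2ccccc2OC1(OCc1cn(-c2ccc(C)cc2)nn1)C(F)(F)F`: 19700 nM

In a functional assay on A549 cells (Homo sapiens) for inhibition, read by MTT assay, with a stated time of 24 h (a higher number here means a weaker inhibitor, a lower number a stronger inhibitor), compound 1 gives > 150000 nM, which is a limit of the assay and not a number. For the measured compounds named here, compound 2 gives 19700 nM in this assay, the only number among the values shown. The other value, that of compound 1, is a limit (the limit of > 150000 nM in this assay, at which 1 of the 2 values shown sits). Compound 3 `CCOC(=O)C1=Cc2ccccc2OC1(OCc1cn(CC(=O)Nc2ccc(C)cc2)nn1)C(F)(F)F` has not been measured; it carries ((4-methylphenyl)carbamoyl)methyl in place of 4-methylphenyl on an aromatic nitrogen. Going by the values given here, no measured pair shows a change of this kind, so the expected step is a 1.5-fold higher number from compound 2 to compound 3 (0.18 log units; within the scatter), small or toward weaker inhibition. Compound 3 is estimated at 30000 nM, between 8000 nM and 150000 nM.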

Compound 3, half-maximal inhibitory concentration: 54300 nM
Compound 3: the middle estimate sits 1.8-fold (0.26 log units) below what was measured; low and high end bracket the measured number.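

In this assay, moving from 4-methylphenyl to ((4-methylphenyl)carbamoyl)methyl on the aromatic nitrogen gives a 2.8-fold higher number from compound 2 to compound 3 (0.44 log units; beyond the scatter), so this position accepts the larger group with a modest move toward weaker inhibition. For the compounds shown here, compound 3 still gives a number and not a limit, which makes this the one readable step at this position. Nothing shown accounts for the size of this step.

From the compounds shown here alone, it remains open whether the carbamoyl unit or the methylene link carries the step. Also open, going by these compounds, is how a benzyl group or a carboxylic acid at this nitrogen would read.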